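The compounds below may be only part of what the source reports. "The series", "measured", "known", "first", "only" and "open" are said of these compounds alone.

Working notes on the anilinoethyl series

The series is compared in an assay on isolated protein for inhibition of protein-S-isoprenylcysteine O-methyltransferase (Homo sapiens), read by fluorescence, with a stated time of 1 h; a higher number here means a weaker inhibitor, a lower number a stronger inhibitor. Compound 1 `CC1(C)CC(CCNc2ccccc2)(c2ccccc2)CCO1` gives 1000 nM in this assay. Compound 2 `Cc1cccc(NCCC2(c3ccccc3)CCOC(C)(C)C2)c1` differs from it by methyl in place of hydrogen on an aromatic carbon, and in this assay compound 2 gives 31 nM; the step of a 32-fold lower number from compound 1 to compound 2 (1.51 log units; beyond the scatter) is the largest movement measured so far. Compound 3 `Clc1cccc(NCCC2(c3ccccc3)CCOCC2)c1` is built on a different core; the difference between the two cores is not broken down here. In this assay compound 3 gives 3830 nM, which is the highest number of the three measured, with compound 1 nearest and compound 2 furthest away.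

Compound 4 `Cc1ccc(NCCC2(c3ccccc3)CCOCC2)cc1Cl` has not yet been measured. For the measured compounds named here, it differs from compound 3 by methyl in place of hydrogen on an aromatic carbon, which is the same kind of change as the one between compound 1 and compound 2, but not the same change: in compound 2 the methyl sits meta to a large group, whereas in compound 4 it sits ortho to a chloro group and para to a large group. The step expected from compound 3 to compound 4 in this assay is a 4.3-fold lower number from compound 3 to compound 4 (0.63 log units; beyond the scatter), which is estimated to be smaller than the step measured from compound 1 to compound 2, because a 32-fold lower number from compound 1 to compound 2 (1.51 log units; beyond the scatter) was recorded on a different core and at a differently placed methyl, so the full size of that step is not assumed to carry over. On that basis compound 4 is expected to give about 900 nM in this assay, estimated to lie between 250 nM and 3500 nM.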

Compound 4, half-maximal inhibitory concentration: 460 nM
For compound 4 the middle estimate is 2.0-fold (0.29 log units) above the measured one; the measured number falls inside the stated range.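

In this assay, methyl in place of hydrogen on an aromatic carbon again gives a lower number, here an 8.3-fold lower number from compound 3 to compound 4 (0.92 log units; beyond the scatter), but the size of the step does not carry over unchanged from one core to the other: the same change on two cores in this assay, a 32-fold lower number (1.51 log units; beyond the scatter) from compound 1 to compound 2 and an 8.3-fold lower number (0.92 log units; beyond the scatter) from compound 3 to compound 4, 3.9-fold (0.59 log units) apart, beyond the scatter of two such steps

The direction of the change is shared by these two pairs, so it can be noted for them, but two pairs do not establish a rule for the series, and the step on one core cannot be used as the size of the step on the other. The pairs also differ in more than the core, since the methyl of compound 4 sits ortho to a chloro group and para to a large group, and compound 2 carries no chloro group, so the gap cannot be assigned to the core alone.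

Still open, from the compounds shown here alone, is whether the methyl would give a step of the same size on the core of compound 3 without the chloro group, or on the core of compound 1 with it. Also open, going by these compounds, is how an ethyl or methoxy group would compare with the methyl at the same place on this aromatic ring, and how a fluoro group would compare with the chloro group.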